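Replacing the aryl group on a shared core

A few compounds are considered here, and "the series" means these few. Any claim that something is new, unique, unknown or untested is made for them only; others in the source may bear on it.

Compound 1 `Cc1oc(-c2c(Cl)cccc2C(F)(F)F)nc1CN1CCC(C(=O)NCCCN2C[C@H](C)C[C@H](C)C2)CC1` and compound 2 `Cc1cccc(-c2nc(CN3CCC(C(=O)NCCCN4C[C@H](C)C[C@H](C)C4)CC3)c(C)o2)c1` share one core and differ only in the aromatic group attached to it. In an ADME assay on Huh7.5.1 cells (Homo sapiens) for cytotoxicity, read by ATP content, with a stated time of 48 h (a lower number here means that less compound is tolerated, a higher number that more compound is tolerated), compound 1 gives 12000 nM, and compound 2 gives 16500 nM. The step of a 1.4-fold higher number from compound 1 to compound 2 (0.14 log units; within the scatter) shows that this exchange changed nothing beyond the scatter, so compound 2 stands at one end of the two measured numbers while its only companion, compound 1, sits within the scatter of it. Compound 3 `COc1cccc(OC)c1-c1nc(CN2CCC(C(=O)NCCCN3C[C@H](C)C[C@H](C)C3)CC2)c(C)o1` carries yet another aromatic group: 2,6-dimethoxyphenyl in place of 3-methylphenyl on an aromatic carbon. Within the data shown here, no measured step involves a 2,6-dimethoxyphenyl, so the only guide is the exchange of aromatic groups between compound 1 and compound 2, which stayed within the scatter. Accordingly, no step beyond the scatter is expected in this assay, in either direction. Compound 3 is therefore estimated at 15000 nM, within a range of 7000 nM to 35000 nM. That estimate corresponds to an expected step of a 1.1-fold lower number from compound 2 to compound 3 (0.04 log units; within the scatter).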

Compound 3, half-maximal cytotoxic concentration: 77100 nM
Estimate against measurement, compound 3: 5.1-fold (0.71 log units) below; measured number outside the range, above it.
By their numbers in this assay, from the lowest: compounds 1 and 2 (each within the scatter of the next); then compound 3.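

In this assay the aromatic group at this position of the shared core turns out to matter: 2,6-dimethoxyphenyl gives a 4.7-fold higher number from compound 2 to compound 3 (0.67 log units; beyond the scatter) and also a 6.4-fold higher number from compound 1 to compound 3 (0.81 log units; beyond the scatter) while the exchange of the other two groups gave only a 1.4-fold higher number from compound 1 to compound 2 (0.14 log units; within the scatter) in the same assay. Among these three compounds, more compound is tolerated only with 2,6-dimethoxyphenyl, the one group of the three that carries oxygen atoms, but three compounds cannot show that the oxygen atoms are what counts. No measurement is available that explains this rise.

The compounds shown leave open whether a 2-methoxyphenyl group, with one methoxy group, would keep the higher number. They also leave open whether a 2,6-dimethylphenyl group, which has methyl groups in place of the methoxy groups, would do the same.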